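Pyridazinone amides on a shared core: cytotoxicity notes

The compounds below may be only part of what the source reports. "The series", "measured", "known", "first", "only" and "open" are said of these compounds alone.

Measured compounds:
- compound 1 `O=C(Nc1ccc(Oc2ccnc3[nH]ccc23)cc1)c1nn(-c2ccc(Cl)c(C(F)(F)F)c2)ccc1=O`: 4630 nM
- compound 2 `COc1ccc(-n2ccc(=O)c(C(=O)Nc3ccc(Oc4ccnc5c4ccn5C)cc3)n2)cc1`: > 60000 nM
- compound 3 `Cn1ccc2c(Oc3ccc(NC(=O)c4nn(-c5ccc(Br)cc5F)ccc4=O)cc3)ccnc21`: 20500 nM

The series is followed in a functional assay on PC-3 cells (Homo sapiens) for cytotoxicity, read by MTT assay, with a stated time of 72 h; on this read-out higher numbers stand for weaker inhibition and lower numbers for stronger inhibition. Compound 1 gives 4630 nM. For compound 2 the result is > 60000 nM, which is a limit of the assay and not a number (the limit of > 60000 nM in this assay, at which 1 of the 3 values shown sits). Compound 3 gives 20500 nM, the higher of the two numbers on record, with compound 1 as the nearer neighbour at a clearly lower number.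

Among the measured compounds shown here, the one step available on the aromatic nitrogen is an at least 2.9-fold lower number from compound 2 to compound 3 (0.46 log units; beyond the scatter); because compound 2 sits at the limit of > 60000 nM in this assay, at which 1 of the 3 values shown sits, its true size is open at the lower end, but its direction is clear. For the measured compounds named here, compound 1 carries the same 4-chloro-3-(trifluoromethyl)phenyl that compound 4 `Cn1ccc2c(Oc3ccc(NC(=O)c4nn(-c5ccc(Cl)c(C(F)(F)F)c5)ccc4=O)cc3)ccnc21` receives, and its number sits well under that of compound 3, though the two also differ in the core and no single step links them.

The change from compound 3 to compound 4 is 4-chloro-3-(trifluoromethyl)phenyl in place of 4-bromo-2-fluorophenyl on an aromatic nitrogen. Taking the halogenated aryl in compound 1 (4630 nM) as the nearest guide, a lower number is expected, roughly a 3.7-fold lower number from compound 3 to compound 4 (0.57 log units; beyond the scatter). Compound 4 is therefore estimated at 5500 nM in this assay, within a range from 1800 nM to 17000 nM.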

Compound 4, half-maximal inhibitory concentration: 10300 nM
Estimate against measurement, compound 4: 1.9-fold (0.27 log units) below, within the range that was stated.
By their numbers in this assay, from the lowest: compound 1; then compounds 4 and 3 (each within the scatter of the next). At a limit, above all of these: compound 2.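

In this assay, this position does not separate 4-chloro-3-(trifluoromethyl)phenyl from 4-bromo-2-fluorophenyl, with a 2.0-fold lower number from compound 3 to compound 4 (0.30 log units; within the scatter), whereas the comparison with 4-methoxyphenyl gives an at least 5.8-fold lower number from compound 2 to compound 4 (0.76 log units; beyond the scatter). The size of that second step is open at one end, since compound 2 carries a limit and not a number: the limit of > 60000 nM in this assay, at which 1 of the 4 values shown sits.

Among the compounds shown here, compound 4 also supplies the first comparison in which only the core changes, with the 4-chloro-3-(trifluoromethyl)phenyl group held constant, and methyl in place of hydrogen on an aromatic nitrogen gives a 2.2-fold higher number from compound 1 to compound 4 (0.35 log units; beyond the scatter).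

From the compounds shown here alone, the methyl step rests on a single pair, and whether it holds with 4-bromo-2-fluorophenyl or 4-methoxyphenyl on the pyridazinone nitrogen stays open. Also open, going by these compounds, is how an aryl group carrying an amine or a carboxylic acid, or a plain alkyl chain in place of the aryl group, would read at this position.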